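From Cyclopropyl to 2-(4-Methylpiperazin-1-yl)ethyl: An Expected Recovery

A few compounds are considered here, and "the series" means these few. Any claim that something is new, unique, unknown or untested is made for them only; others in the source may bear on it.

Going by the values given here, compound 2 `COc1ncc(-c2ccc3nc(NC(=O)NC4CC4)sc3c2)cc1NS(=O)(=O)c1ccc(F)cc1` gives 1190 nM in a functional assay on MCF7 cells (Homo sapiens) for antiproliferative activity, read by MTT assay, with a stated time of 72 h (a higher number here means a weaker inhibitor, a lower number a stronger inhibitor), the higher of the two numbers measured so far; its nearest neighbour, compound 1 `COc1ncc(-c2ccc3nc(NC(=O)NCCN(C)C)sc3c2)cc1NS(=O)(=O)c1ccc(F)cc1`, gives 500 nM. Among the compounds with values here, the one measured step, a 2.4-fold higher number from compound 1 to compound 2 (0.38 log units; beyond the scatter), shows that putting cyclopropyl in place of 2-(dimethylamino)ethyl weakened inhibition modestly. Compound 3 `COc1ncc(-c2ccc3nc(NC(=O)NCCN4CCN(C)CC4)sc3c2)cc1NS(=O)(=O)c1ccc(F)cc1` moves the other way: 2-(4-methylpiperazin-1-yl)ethyl in place of cyclopropyl on an amide-type nitrogen. The entering chain resembles the 2-(dimethylamino)ethyl group of compound 1 far more than it does cyclopropyl, and a downward step of roughly the size of a 2.4-fold higher number from compound 1 to compound 2 (0.38 log units; beyond the scatter) is expected. Compound 3 is therefore estimated at 550 nM, within 250 nM to 1300 nM, corresponding to a 2.2-fold lower number from compound 2 to compound 3 (0.34 log units; beyond the scatter).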

Compound 3, half-maximal inhibitory concentration: 470 nM
For compound 3 the middle estimate is 1.2-fold (0.07 log units) above the measured one; low and high end bracket the measured number.
By their numbers in this assay, from the lowest: compounds 3 and 1 (each within the scatter of the next); then compound 2.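

In this assay, 2-(4-methylpiperazin-1-yl)ethyl in place of cyclopropyl on the amide-type nitrogen gives a 2.5-fold lower number from compound 2 to compound 3 (0.40 log units; beyond the scatter), so a second chain, not only the 2-(dimethylamino)ethyl of compound 1, gives a lower number than cyclopropyl. With 4-methylpiperazin-1-yl in place of dimethylamino, the result is a 1.1-fold lower number from compound 1 to compound 3 (0.03 log units; within the scatter), and this assay does not tell these two chain ends apart. No measurement shown accounts for either step. On these data alone, what a morpholin-4-yl group or a hydroxyl at the end of the ethyl chain would give remains open, as does a longer chain carrying dimethylamino.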